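A cyclohexyl in place of the thiazolylmethyl on compound 2

The compounds below may be only part of what the source reports. "The series", "measured", "known", "first", "only" and "open" are said of these compounds alone.

Compound 2 `Cc1nc(C)c(Cn2ncc3c(Nc4ccc(OC(F)(F)F)cc4)ncnc32)s1` gives in an ADME assay on BaF3 cells (Mus musculus) for cytotoxicity (on this read-out lower numbers stand for an effect already at smaller amounts and higher numbers for an effect only at larger amounts of compound), only a limit of the assay, > 10000 nM, and no number. The same holds for compound 3 `CCNC(=O)c1cc2c(Nc3ccc(OC(F)(F)F)cc3)ncnc2s1`, which in this assay gives the limit > 10000 nM. Compound 1 `CN1CCN(C(=O)c2cc3c(Nc4ccc(OC(F)(F)F)cc4)ncnc3s2)CC1` in this assay gives 2690 nM. Compound 2 thus stands at the limit of > 10000 nM in this assay, at which 2 of the 3 values shown sit, together with compound 3, while compound 1 is the only one of the three that gives a number.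

Compound 4 `FC(F)(F)Oc1ccc(Nc2ncnc3c2cnn3C2CCCCC2)cc1` differs from compound 2 in one place: cyclohexyl in place of (2,4-dimethyl-1,3-thiazol-5-yl)methyl on an aromatic nitrogen. Going by the values given here, the only measured step, an at least 3.7-fold higher number from compound 1 to compound 3 (0.57 log units; beyond the scatter), concerns another place on the shared core, and no step on the aromatic nitrogen has been measured. That step shows that exchanging the group on the carbonyl carbon can move the number beyond the scatter, up to the limit. Among the compounds with values here, no step shows a move downward from the limit. Compound 4 is therefore expected to remain near the limit, and the step of a number no higher from compound 2 to compound 4 (the limit leaves the size open) is expected to be none beyond the scatter. The estimate for compound 4 is 10000 nM, within a range from 3000 nM to 30000 nM, with a real chance that only a limit is reported.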

Compound 4, half-maximal effective concentration: 9300 nM
Compound 4: the middle estimate sits 1.1-fold (0.03 log units) above what was measured, within the range that was stated.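

In this assay, the exchange of (2,4-dimethyl-1,3-thiazol-5-yl)methyl for cyclohexyl gives the only step shown on this aromatic nitrogen, an at least 1.0-fold lower number from compound 2 to compound 4 (0.03 log units; that floor lies within the scatter), and the floor of that step lies within the scatter. Its true size cannot be read, since compound 2 gives a limit of the assay and not a number: the limit of > 10000 nM in this assay, at which 2 of the 4 values shown sit. The pair therefore adds a number for a compound with a group on this aromatic nitrogen, and it shows that a six-membered non-aromatic ring of carbon only can stand at this place in compound 4 with a measurable read-out, but it neither proves nor rules out a shift beyond the scatter.

The compounds shown leave open how far the number depends on the group on this aromatic nitrogen, since a piperidine, a short alkyl chain or a simple hydrogen is not among them at this place. As far as these compounds go, whether an amine or a carboxylic acid carried on the cyclohexyl would move the number away from that of compound 4 also remains open.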